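A few compounds are considered here, and "the series" means these few. Any claim that something is new, unique, unknown or untested is made for them only; others in the source may bear on it.

Compound 1, `Cc1ccc(-c2n[nH]cc2N2CCCNCC2)cc1`, gives a limit rather than a number in an assay on isolated protein for binding affinity to 5-hydroxytryptamine receptor 1E (Homo sapiens); on this read-out higher numbers stand for weaker inhibition and lower numbers for stronger inhibition: > 10000 nM. Compound 2, `Fc1ccc(-c2n[nH]cc2N2CCCNCC2)cc1`, likewise gives only a limit in this assay: > 10000 nM. Compound 3, `COc1cccc(-c2n[nH]cc2N2CCNCC2)c1`, also returns a limit in this assay: > 10000 nM.

Compound 3 therefore stands at the limit of > 10000 nM in this assay, at which 3 of the 3 values shown sit, and the numbers shown give it no place above or below the other two. Among the compounds with values here, the one step that can be drawn between measured compounds, a step that the two limits leave unreadable from compound 1 to compound 2, is a change of fluoro in place of methyl on an aromatic carbon. Both of its ends are limits, and its size cannot be read. Within the data shown here, the three values shown thus hold no readable step at all, and no measured step bears directly on the change that leads to compound 4.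

Compound 4, `c1ccc(-c2n[nH]cc2N2CCNCC2)cc1`, differs from compound 3 by hydrogen in place of methoxy on an aromatic carbon. With every measured value sitting at a limit, there is no basis for expecting the removal of methoxy to bring the value into the measurable range, so the expected step from compound 3 to compound 4 is a step that the limit leaves unreadable from compound 3 to compound 4, which is to say none that could be read. Compound 4 is accordingly estimated at 15000 nM, with a range from 5000 nM to 50000 nM, most likely reported again as a limit.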

Compound 4, inhibition constant: > 10000 nM
Compound 4 gave a limit, no number (the forecaster's own chance of this, stated with the estimate: 85%); the middle value does not contradict the limit.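

Within the data shown here, the step between compound 3 and compound 4 cannot be read, as both give only limits in this assay, so this result adds no new step. The compounds shown leave open what effect, if any, hydrogen in place of methoxy on an aromatic carbon has, and how far any of the four lies beyond its limit.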